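Thiophenyl for cyanophenyl: expectation for compound 4

The source may report more compounds than this note shows. Statements on the series, on what has been measured and on what is new or still open speak of the compounds shown alone.

Measured so far:
compound 1 `O=C(O)c1cc(-n2c(-c3ccccc3)cc3c2CCCC3)ccc1O` — >= 60%
compound 2 `COc1ccc(-c2cc3c(n2-c2ccc(O)c(C(=O)O)c2)CCCC3)cc1` — 50%
compound 3 `N#Cc1ccc(-c2cc3c(n2-c2ccc(O)c(C(=O)O)c2)CCCC3)cc1` — 0%

In a functional assay on the whole organism (strain Wistar) for inhibition, with Rattus norvegicus as the target, read by paw edema, with stated times of 30 min and 3 h, at a dose of 200 mg/kg by the oral route (a lower number here means less inhibition, a higher number more inhibition at the dose given (going by the name of the read-out)), compound 3 has the lowest of the two numbers; its nearest neighbour is compound 2, with a number 50 percentage points lower from compound 2 to compound 3 (beyond the scatter). For compound 1 the read-out is the limit of >= 60% in this assay, at which 1 of the 3 values shown sits, a limit rather than a number. Compound 4 `O=C(O)c1cc(-n2c(-c3cccs3)cc3c2CCCC3)ccc1O` differs from compound 3 in one place: thiophen-2-yl in place of 4-cyanophenyl on an aromatic carbon. The measured steps that bear on this change are those introducing the cyano group, a number at least 60 percentage points lower from compound 1 to compound 3 (beyond the scatter) and a number 50 percentage points lower from compound 2 to compound 3 (beyond the scatter), both large and beyond the scatter. Taking the cyano-bearing ring away is thus expected to raise the read-out; thiophen-2-yl itself has no measured counterpart in the series, so the size is uncertain. Compound 4 is expected to give 40%, between 15% and 65%, meaning a number 40 percentage points higher from compound 3 to compound 4 (beyond the scatter).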

Compound 4, a percentage reported as inhibition, in the whole organism at one dose (the size of the read-out at that dose, not a potency): 30%
Compound 4: middle estimate off by 10 percentage points, on the high side, and the stated range covers the measured number.
By their numbers in this assay, from the lowest: compound 3; then compound 4; then compound 2. At a limit, above all of these: compound 1.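

In this assay, this aromatic carbon next to the ring nitrogen accepts a five-membered aromatic ring with some response kept: thiophen-2-yl in place of 4-cyanophenyl gives a number 30 percentage points higher from compound 3 to compound 4 (beyond the scatter). Thiophen-2-yl still trails the six-membered rings without a nitrile, with a number 20 percentage points lower from compound 2 to compound 4 (beyond the scatter) and a number at least 30 percentage points lower from compound 1 to compound 4 (beyond the scatter). Compound 1 carries a limit rather than a number, so that last step has only a floor: the limit of >= 60% in this assay, at which 1 of the 4 values shown sits.

Open, from the compounds shown here alone, is whether thiophen-3-yl matches thiophen-2-yl here, and whether a group without a ring, such as an amine or a longer alkyl chain, keeps any of the read-out.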